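Replacing Fluoro with Hydrogen on Compound 1

The source may hold more compounds than are shown below. What is called first, only, known or untested is meant among the compounds shown, and "the series" means these compounds.

Measured in a physicochemical assay for lipophilicity, at pH 7.4; on this read-out lower numbers stand for lower lipophilicity and higher numbers for higher lipophilicity:
compound 1 `COc1cccc(C(=O)NCc2c(C)cc(C)[nH]c2=O)c1F` gives 1.4
compound 2 `Cc1cc(C)c(CN2CCc3c(F)cc(O[C@@H]4CCOC4)c(Cl)c3C2=O)c(=O)[nH]1` gives 2.1

Compound 1 holds the lower of these two numbers, and the gap up to compound 2 lies beyond the scatter. The next compound, compound 3 `COc1cccc(C(=O)NCc2c(C)cc(C)[nH]c2=O)c1`, has not yet been measured. It departs from compound 1 in one place: hydrogen in place of fluoro on an aromatic carbon, ortho to a large group and ortho to a methoxy group. Going by the values given here, no measured pair shows this change on its own. A small fall, within the scatter, is expected as a number 0.20 log units lower from compound 1 to compound 3 (within the scatter) in this assay on this estimate. For compound 3 the expected value is 1.2 with 0.8 to 1.5 as its estimated range.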

Compound 3, distribution coefficient: 1.7
The estimate for compound 3 lay 0.50 log units below the measured number; the whole stated range lies below it.
By their numbers in this assay, from the lowest: compounds 1 and 3 (each within the scatter of the next); then compound 2.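

Hydrogen in place of fluoro on this aromatic carbon, ortho to a large group and ortho to a methoxy group, now has a direct reading in this assay as a number 0.30 log units higher from compound 1 to compound 3 (within the scatter) for this single change. On this core, the assay therefore does not separate the two compounds. Nothing available here bears on the reason for this result.

The compounds shown leave open how a nitrile or an amine on this carbon would read in this assay and whether the same swap would give a similar step on the core of compound 2.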